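Weak amides with a shared core: oxazole to chloropyridine

This account rests on a few compounds, and the source may have more. Where it says the series, first, only, none or still open, it means among the compounds named here.

In a functional assay on AN3-CA cells (Homo sapiens) for antiproliferative activity, read by MTT assay, with a stated time of 72 h (a lower number here means a stronger inhibitor, a higher number a weaker inhibitor), compound 3 `O=C(Nc1ccc(Cl)c(-c2nnc3c(Cl)cccn23)c1)c1ccon1` gives only a limit, > 100000 nM. Its phenyl counterpart, compound 2 `O=C(Nc1ccc(Cl)c(-c2nnc3c(Cl)cccn23)c1)c1ccccc1`, gives 67600 nM. Compound 1 `CS(=O)(=O)c1ccc(C(=O)Nc2ccc(Cl)c(-c3nnc4c(Cl)cccn34)c2)c(Cl)c1` likewise reaches only a limit, > 100000 nM. Among the compounds with values here, the single measured step within this set, an at least 1.4-fold higher number from compound 2 to compound 3 (0.17 log units; that floor lies within the scatter), is small. Compound 4 `O=C(Nc1ccc(Cl)c(-c2nnc3c(Cl)cccn23)c1)c1cccnc1Cl` differs from compound 3 by 2-chloropyridin-3-yl in place of 1,2-oxazol-3-yl on a carbonyl carbon. Within the data shown here, no measured step covers this exact change; the only known one, phenyl to 1,2-oxazol-3-yl, barely moved the number. Because the limit of > 100000 nM in this assay, at which 2 of the 3 values shown sit, marks where two of the three values sit, the whole set is weak. Compound 4 is therefore expected to remain weak, an expected step of an at least 1.1-fold lower number from compound 3 to compound 4 (0.04 log units; that floor lies within the scatter). Compound 4 is estimated at 90000 nM, between 30000 nM and 200000 nM.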

Compound 4, half-maximal inhibitory concentration: > 100000 nM
Compound 4: no number, only a limit (the forecaster's own chance of this, stated with the estimate: 50%); middle value at least 1.1-fold (0.04 log units) away from the limit.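

Replacing phenyl on the carbonyl carbon with 2-chloropyridin-3-yl gives an at least 1.4-fold higher number from compound 2 to compound 4 (0.17 log units; that floor lies within the scatter), so a second ring swap at this place also shows no step beyond the scatter. The step between compound 3 and compound 4 cannot be read, as both values are limits. With this third group on the carbonyl carbon, most of the set now rests at one ceiling: the limit of > 100000 nM in this assay, at which 3 of the 4 values shown sit.

On these data alone, how a ring carrying an amine or a carboxylic acid would read at this place stays open. So does whether any change here alone can bring the shared core clear of the limit.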